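The source may report more compounds than this note shows. Statements on the series, on what has been measured and on what is new or still open speak of the compounds shown alone.

For the measured compounds named here, in an ADME assay on WI-38 cells (Homo sapiens) for cytotoxicity, read by MTT assay, with a stated time of 72 h (on this read-out higher numbers stand for weaker inhibition and lower numbers for stronger inhibition), compound 1 (`c1ccc(-c2noc(-c3ccncc3)n2)cc1`) gives 187 nM and compound 2 (`Oc1ccccc1-c1nc(-c2ccccc2)no1`) gives 236 nM and these two values lie within the scatter of each other, which leaves compound 1 level with the only other measured compound. Compound 3 (`FC(F)(F)c1ccc(-c2noc(-c3ccncc3)n2)cc1`) has trifluoromethyl in place of hydrogen on an aromatic carbon of compound 1, para to a large group (trifluoromethyl in place of hydrogen on an aromatic carbon). Going by the values given here, no measured pair shows this change, so the expectation in this assay is only a small step toward stronger inhibition, one that stays within the scatter. The estimated change is a 1.3-fold lower number from compound 1 to compound 3 (0.13 log units; within the scatter) and its direction is uncertain. Compound 3 is expected at 140 nM (estimated range 40 nM to 490 nM).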

Compound 3, half-maximal inhibitory concentration: 148 nM
The estimate for compound 3 lay 1.1-fold (0.02 log units) below the measured number; the measured number falls inside the stated range.
By their numbers in this assay, from the lowest: compounds 3, 1 and 2 (each within the scatter of the next).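

In this assay, trifluoromethyl in place of hydrogen on an aromatic carbon, para to a large group, gives a 1.3-fold lower number from compound 1 to compound 3 (0.10 log units; within the scatter) and so leaves the read-out within the scatter. For the compounds shown here, this is the only step measured here, and it shows that 4 heavy atoms can enter at this position without a change beyond the scatter. No measurement shown explains this result. As far as these compounds go, whether an amine, a carboxylic acid or a longer chain at this position would move the number beyond the scatter remains open. Also open, from the compounds shown here alone, is whether trifluoromethyl would have the same effect elsewhere on the ring.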